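The source may hold more compounds than are shown below. What is called first, only, known or untested is meant among the compounds shown, and "the series" means these compounds.

Measured so far in an ADME assay on TZM cells (Homo sapiens) for cytotoxicity, read by CCK-8 assay, with a stated time of 2 days; on this read-out higher numbers stand for lower toxicity in this test and lower numbers for higher toxicity in this test:
Compound 1 `COc1ccc(C(=O)Nc2ccc(CCS(=O)(=O)/C=C/c3ccc(O)c(O)c3)cc2)cc1`: > 1000000 nM, a limit
Compound 2 `O=C(Nc1ccc(CCS(=O)(=O)/C=C/c2ccc(O)c(O)c2)cc1)c1ccc(F)cc1`: > 1000000 nM, a limit
Compound 3 `O=C(Nc1ccc(CCS(=O)(=O)/C=C/c2ccc(O)c(O)c2)cc1)C1CCCCC1`: 638000 nM

Compound 3 is the only one of the three with an actual number. Compound 1 and compound 2 stand at the limit of > 1000000 nM in this assay, at which 2 of the 3 values shown sit.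

The next compound, compound 4 `Cc1ccc(C(=O)Nc2ccc(CCS(=O)(=O)/C=C/c3ccc(O)c(O)c3)cc2)cc1`, keeps the shared core and carries 4-methylphenyl in place of cyclohexyl on a carbonyl carbon.

Going by the values given here, two measured steps bear on this change, since both exchange an aromatic group and cyclohexyl at that same carbonyl carbon. They are an at least 1.5-fold lower number from compound 1 to compound 3 (0.19 log units; that floor lies within the scatter) and an at least 1.5-fold lower number from compound 2 to compound 3 (0.19 log units; that floor lies within the scatter). Both run in the opposite sense to the new step, and neither shows a gap beyond the scatter. The third step, a step that the two limits leave unreadable from compound 1 to compound 2, has fluoro in place of methoxy on an aromatic carbon and gives no size to work with.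

Going by an at least 1.5-fold lower number from compound 2 to compound 3 (0.19 log units; that floor lies within the scatter), read in reverse, compound 4 is expected to sit close to the limit in this assay, and it may well be reported only as a limit. The expected change is a 1.6-fold higher number from compound 3 to compound 4 (0.20 log units; within the scatter), pointing upward but staying within the scatter. For compound 4 the estimate is 1000000 nM, with an expected range of 600000 nM to 2000000 nM.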

Compound 4, half-maximal cytotoxic concentration: 168000 nM
Beside the measured number, compound 4's estimate is 6.0-fold (0.77 log units) above it, and the stated range ends above it.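

In this assay, the exchange on the carbonyl carbon now gives a step beyond the scatter, a 3.8-fold lower number from compound 3 to compound 4 (0.58 log units; beyond the scatter), and it makes compound 4 the lowest number of the four, which means the highest toxicity in this test. An aromatic ring at this carbonyl carbon therefore does not by itself keep the number high, since the group on that ring also counts: methyl in place of fluoro gives an at least 5.9-fold lower number from compound 2 to compound 4 (0.77 log units; beyond the scatter), and methyl in place of methoxy gives an at least 5.9-fold lower number from compound 1 to compound 4 (0.77 log units; beyond the scatter), both beyond the scatter. Those two steps give only a minimum size, as compound 1 and compound 2 are reported only as a limit: the limit of > 1000000 nM in this assay, at which 2 of the 4 values shown sit.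

As far as these compounds go, the step between compound 1 and compound 2 cannot be read, so fluoro and methoxy cannot be ranked against each other, and the true size of their gaps to methyl remains unknown. From the compounds shown here alone, it also remains open whether the lower number belongs to methyl alone or would also appear with a chloro, ethyl or amino group on that aromatic carbon, or with an unsubstituted phenyl ring on the carbonyl carbon.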